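A few compounds are considered here, and "the series" means these few. Any claim that something is new, unique, unknown or untested is made for them only; others in the source may bear on it.

Three compounds built on a shared core were examined in a functional assay on the whole organism (artery, strain albino) with Rattus norvegicus as the target, with a stated time of 180 min, at a dose of 10 mg/kg by the oral route; on this read-out lower numbers stand for less inhibition and higher numbers for more inhibition at the one dose given (going by the name of the read-out). Compound 1 `CC1=C(C(=O)Nc2ccc(Br)cc2)C(c2ccc(Cl)cc2Cl)N=C(SCc2ccccc2)N1` gives 13.4% in this assay. Compound 2 `CC1=C(C(=O)Nc2ccc(Br)cc2)C(c2ccc(Cl)cc2Cl)N=C(SCc2cccc(Cl)c2)N1` carries chloro in place of hydrogen on an aromatic carbon, and in this assay compound 2 gives 11.9%; the read-out moves by a number 1.5 percentage points lower from compound 1 to compound 2 (within the scatter). Compound 3 `CC1=C(C(=O)Nc2ccc([N+](=O)[O-])cc2)C(c2cccc([N+](=O)[O-])c2)N=C(SCc2ccccc2)N1` gives 16.5% in this assay; the difference between its core and the core of compound 1 is not broken down here, and its number lies within the scatter of the numbers of compound 1 and compound 2.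

Compound 4 `CC1=C(C(=O)Nc2ccc([N+](=O)[O-])cc2)C(c2cccc([N+](=O)[O-])c2)N=C(SCc2ccccc2Cl)N1` has not yet been measured. It differs from compound 3 by chloro in place of hydrogen on an aromatic carbon. Within the data shown here, this is the same kind of change as the one from compound 1 to compound 2, but not the same change: in compound 2 the chloro sits meta to a large group, whereas in compound 4 it sits ortho to a large group. For compound 4 the expected step is a number 1.5 percentage points lower from compound 3 to compound 4 (within the scatter), because the same kind of change earlier gave a number 1.5 percentage points lower from compound 1 to compound 2 (within the scatter). Compound 4 is therefore estimated to give 15% in this assay, with a likely range from 5% to 27%.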

Compound 4, a percentage reported as inhibition, in the whole organism at one dose (the size of the read-out at that dose, not a potency): 9.3%
Compound 4: middle estimate off by 5.7 percentage points, on the high side; the measured number falls inside the stated range.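

In this assay the chloro change gives a number 7.2 percentage points lower from compound 3 to compound 4 (within the scatter), and set beside the earlier step it does not differ from that step by more than two such steps would scatter: the same change on two cores in this assay, a number 1.5 percentage points lower (within the scatter) from compound 1 to compound 2 and a number 7.2 percentage points lower (within the scatter) from compound 3 to compound 4, 5.7 percentage points apart, within the scatter of two such steps

The two cores therefore give no sign that the change behaves differently from one to the other, and since neither step stands clear of the scatter, no effect of the chloro on the read-out is shown on either core. Nor does this show that the change carries over at the same size: only two pairs are at hand, they were read at a single dose, and the chloro of the 2-chlorobenzyl group in compound 4 does not sit at the same place on the ring as the chloro in compound 2.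

Left open is whether a methoxy group or a dimethylamino group on that ring, or a longer chain such as phenethyl in place of benzyl, would give a step beyond the scatter. Also open is how any of these compounds would read at another dose.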